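Ether for amide linker on the aryl arm of the core

This account rests on a few compounds, and the source may have more. Where it says the series, first, only, none or still open, it means among the compounds named here.

Compound 1 `COc1ncc(N2CCc3ncnc(O[C@H]4CCN(C(=O)C5CCOCC5)C4)c3C2)cc1C`: 4150 nM
Compound 2 `COc1ccc(N2CCc3ncnc(-c4cccc(C(=O)N5CCN(C(C)=O)CC5)c4)c3C2)cn1`: > 9100 nM

In an ADME assay on isolated protein for inhibition of phosphatidylinositol 4,5-bisphosphate 3-kinase catalytic subunit beta isoform (Homo sapiens), read by Kinase-Glo, with a stated time of 60 min (a lower number here means a stronger inhibitor, a higher number a weaker inhibitor), compound 1 gives 4150 nM. Compound 2 returns only a limit in this assay, > 9100 nM. Compound 2 thus sits at the limit of > 9100 nM in this assay, at which 1 of the 2 values shown sits; no number is known for it, only that it lies outside the measured range. Among the compounds with values here, compound 1 and compound 2 differ in more than one place, so their two values show only that compound 1 has a number while compound 2 has none.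

Compound 3 `COc1ccc(N2CCc3ncnc(-c4cccc(OC5CCN(C(C)=O)CC5)c4)c3C2)cn1` is the unmeasured follow-on to compound 2: (1-acetylpiperidin-4-yl)oxy in place of (4-acetylpiperazin-1-yl)carbonyl on an aromatic carbon. Within the data shown here, no step between two measured compounds covers this change, so its size and direction have nothing measured to lean on. Compound 3 is expected to stay weak and close to the limit, estimated at 8000 nM with a range of 2500 nM to 25000 nM. The step implied by this estimate, an at least 1.1-fold lower number from compound 2 to compound 3 (0.05 log units; that floor lies within the scatter), is expected to be no larger than the scatter, with a real chance that this assay again returns only a limit.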

Compound 3, half-maximal inhibitory concentration in the phosphatidylinositol 4,5-bisphosphate 3-kinase catalytic subunit beta isoform assay: > 9100 nM
Compound 3: no number, only a limit (the forecaster's own chance of this, stated with the estimate: 50%); middle value at least 1.1-fold (0.05 log units) away from the limit.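

In the phosphatidylinositol 4,5-bisphosphate 3-kinase catalytic subunit beta isoform assay compound 2 returns only a limit, > 9100 nM. In the phosphatidylinositol 4,5-bisphosphate 3-kinase catalytic subunit beta isoform assay compound 3 also returns only a limit, > 9100 nM. In a physicochemical assay for solubility, read by LC-MS, measured as thermodynamic solubility, at pH 6.8 (on this read-out higher numbers stand for higher solubility and lower numbers for lower solubility), compound 2 returns only a limit, > 1000000 nM. In the physicochemical assay compound 3 also returns only a limit, > 1000000 nM. So no step between them can be read. The compounds shown leave open what number either compound would reach in the phosphatidylinositol 4,5-bisphosphate 3-kinase catalytic subunit beta isoform assay, and whether (1-acetylpiperidin-4-yl)oxy and (4-acetylpiperazin-1-yl)carbonyl on the aromatic carbon differ at all.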